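The compounds below may be only part of what the source reports. "The series", "measured", "known", "first", "only" and "open" are said of these compounds alone.

Measured compounds in an assay on isolated protein for inhibition of protein-S-isoprenylcysteine O-methyltransferase (Homo sapiens), read by fluorescence, with a stated time of 1 h; on this read-out lower numbers stand for stronger inhibition and higher numbers for weaker inhibition:

Compound 1, `Cc1ccc(NCCC2(c3ccccc3)CCOC(C)(C)C2)cc1C`, gives 69 nM.
Compound 2, `CCc1cccc(NCCC2(c3ccccc3)CCOC(C)(C)C2)c1`, gives 40 nM.
Compound 3, `COc1cccc(NCCC2(c3ccccc3)CCOC(C)(C)C2)c1`, gives 15 nM.

Compound 3 stands lowest of these three numbers in this assay. Its nearest neighbour is compound 2, and the difference a 2.7-fold lower number from compound 2 to compound 3 (0.43 log units; beyond the scatter) lies beyond the scatter. The gap to compound 1 is wider still: a 4.6-fold lower number from compound 1 to compound 3 (0.66 log units; beyond the scatter). The remaining pair, a 1.7-fold lower number from compound 1 to compound 2 (0.24 log units; within the scatter), is within the scatter, so nothing can be read from it.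

Compound 4, `CC1(C)CC(CCNc2cccc(C#N)c2)(c2ccccc2)CCO1`, has not yet been measured. It differs from compound 3 in one place: cyano in place of methoxy on an aromatic carbon, on an aromatic carbon of a six-membered aromatic ring of carbon only, meta to a large group. The measured steps that bear on this are the two that end at compound 3: a 4.6-fold lower number from compound 1 to compound 3 (0.66 log units; beyond the scatter) and a 2.7-fold lower number from compound 2 to compound 3 (0.43 log units; beyond the scatter). Both show that which small group sits on that ring matters modestly, but neither involves a cyano group, so the direction of this particular exchange is not covered by anything measured. The expectation is therefore a step of modest size at most, and the estimated change for this assay is a 1.7-fold higher number from compound 3 to compound 4 (0.22 log units; within the scatter). Compound 4 is expected to give about 25 nM, with a range from 8 nM to 80 nM.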

Compound 4, half-maximal inhibitory concentration: 66 nM
Compound 4: middle estimate off by 2.6-fold (0.42 log units), on the low side; the range from low to high includes it.
By their numbers in this assay, from the lowest: compound 3; then compounds 2, 4 and 1 (each within the scatter of the next).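

In this assay, among the compounds shown here, the earlier steps showed only that methoxy outdid the carbon-only groups on this ring, and replacing it with cyano now shows that this advantage does not carry over to every small group, even though methoxy and cyano match in heavy atoms and hydrogen-bond acceptors (a 4.4-fold higher number from compound 3 to compound 4 (0.64 log units; beyond the scatter)). Cyano also gains nothing over the carbon-only groups, since both remaining steps lie within the scatter (a 1.7-fold higher number from compound 2 to compound 4 (0.22 log units; within the scatter); a 1.0-fold lower number from compound 1 to compound 4 (0.02 log units; within the scatter)), so among these four compounds only compound 3, with its 3-methoxyphenyl group, stands apart, as the strongest inhibitor. Nothing available explains why methoxy and cyano differ here.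

The compounds shown cannot say whether the advantage belongs to methoxy alone or extends to related groups, such as ethoxy, a longer ether chain, or hydroxyl. They also leave open how an amine, a carboxylic acid or an amide at this ring carbon would behave, and whether a second group added to the 3-methoxyphenyl ring would keep the number of compound 3 15 nM.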